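From diethylamino to pyrrolidin-1-yl: a step among limits

The source may report more compounds than this note shows. Statements on the series, on what has been measured and on what is new or still open speak of the compounds shown alone.

Measured in an ADME assay on MT4 cells (Homo sapiens) for cytotoxicity, read by MTT assay, with a stated time of 4 days; a lower number here means that less compound is tolerated, a higher number that more compound is tolerated:
Compound 1 `O=c1cc(Cc2c(F)cccc2F)nc(N2CCCC2)[nH]1` gives the limit > 86000 nM only
Compound 2 `Cc1c(Cc2c(F)cccc2F)nc(N(C)c2ccccc2)[nH]c1=O` gives the limit > 73000 nM only
Compound 3 `CCN(CC)c1nc(Cc2c(F)cccc2F)c(C)c(=O)[nH]1` gives the limit > 81000 nM only

Compound 3 stands at the limit of > 81000 nM in this assay, at which 1 of the 3 values shown sits, and has no number of its own. The other two values are limits as well, so nothing here ranks the three compounds. The next step swaps diethylamino for pyrrolidin-1-yl on an aromatic carbon, between two ring nitrogen atoms, and gives compound 4 `Cc1c(Cc2c(F)cccc2F)nc(N2CCCC2)[nH]c1=O` (pyrrolidin-1-yl in place of diethylamino on an aromatic carbon). Among the measured compounds shown here, the only measured step bearing on this change is a step that the two limits leave unreadable from compound 2 to compound 3, which offers no size to carry over. Compound 1 already carries pyrrolidin-1-yl, and its value is also a limit (> 86000 nM). In this assay, the expected change is therefore none beyond the scatter, with no direction favoured, and the estimated step is a step that the limit leaves unreadable from compound 3 to compound 4 here. Compound 4 is estimated at 82000 nM, with an expected range from 50000 nM to 100000 nM, and will most likely be reported as a limit too.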

Compound 4, half-maximal cytotoxic concentration: > 82000 nM
Compound 4 was reported as a limit (the forecaster's own chance of this, stated with the estimate: 85%); the middle value lies on the limit itself.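

In this assay compound 4 gives > 82000 nM, which is a limit. Among the compounds shown here, the values of compound 1, compound 2 and compound 3 are limits too, so no step to compound 4 can be read. The compounds shown leave open whether any of these changes shifts the half-maximal cytotoxic concentration at all.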